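A few compounds are considered here, and "the series" means these few. Any claim that something is new, unique, unknown or untested is made for them only; others in the source may bear on it.

Compound 1 `O=C(CN1CCN(C(=O)c2ccc(F)cc2)CC1)N1CCN(CCCc2c[nH]c3ccccc23)CC1` and compound 2 `O=C(CN1CCN(C(=O)c2ccc(Br)cc2)CC1)N1CCN(CCCc2c[nH]c3ccc(F)cc23)CC1` have both been tested in an ADME assay on SH-SY5Y cells (Homo sapiens) for cytotoxicity, read by MTT assay, with a stated time of 72 h; a higher number here means a weaker inhibitor, a lower number a stronger inhibitor. In that test compound 1 gives 188000 nM and compound 2 gives 47400 nM. Compound 2 therefore holds the lower of the two numbers, and the gap lies beyond the usual scatter of repeated measurements. The two compounds differ in more than one place, so the gap cannot be assigned to any single group.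

Compound 3 `O=C(CN1CCN(C(=O)c2ccc(F)cc2)CC1)N1CCN(CCCc2c[nH]c3ccc(F)cc23)CC1` has not yet been measured. It departs from compound 2 in one place: fluoro in place of bromo on an aromatic carbon. This puts fluoro in place of bromo on an aromatic carbon, turning 4-bromophenyl into 4-fluorophenyl. Among the compounds with values here, no measured pair shows this exact swap, so any forecast is loose. Within the data shown here, the only other reference is compound 1 at 188000 nM, which points towards a higher number. A moderate rise is therefore expected in this assay, roughly at the edge of the scatter or a little beyond it. The estimated change is a 1.9-fold higher number from compound 2 to compound 3 (0.28 log units; within the scatter). For compound 3 the estimated value is 90000 nM, with an expected range from 40000 nM to 190000 nM.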

Compound 3, half-maximal inhibitory concentration: 121000 nM
Compound 3: the middle estimate sits 1.3-fold (0.13 log units) below what was measured, within the range that was stated.
By their numbers in this assay, from the lowest: compound 2; then compounds 3 and 1 (each within the scatter of the next).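

In this assay, the swap of 4-bromophenyl to 4-fluorophenyl can now be read on its own, with the rest of the molecule held fixed: a 2.6-fold higher number from compound 2 to compound 3 (0.41 log units; beyond the scatter). This is a modest step, but it shows that the group on this aromatic carbon, para to a large group, can move the number by more than repeat measurements would. The second single change, the addition of fluoro elsewhere in the shared core, gives a 1.6-fold lower number from compound 1 to compound 3 (0.19 log units; within the scatter), which stays within the scatter, so of these two single changes only the swap of bromo for fluoro shows a clear difference.

With only bromo and fluoro compared at this position, the compounds shown leave open how chloro, methoxy, an amine or plain hydrogen on the same carbon would compare, and so whether any trend runs across such groups. Nothing shown here bears on what lies behind the step seen with this swap.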